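Dropping the Chloro Group: From Compound 2 to Compound 3

The compounds below may be only part of what the source reports. "The series", "measured", "known", "first", "only" and "open" are said of these compounds alone.

Measured so far:
compound 1 `O=C(/C=C/c1cccc([N+](=O)[O-])c1)c1ccc2ccccc2c1` — 14000 nM
compound 2 `O=C(/C=C/c1cccc(Cl)c1)c1ccc2ccccc2c1` — 10000 nM

Both numbers come from a functional assay on L1210 cells (Mus musculus) for cytotoxicity, read by MTT assay, with a stated time of 72 h; on this read-out higher numbers stand for weaker inhibition and lower numbers for stronger inhibition. Compound 2 stands alongside compound 1 rather than apart from it: the step of a 1.4-fold lower number from compound 1 to compound 2 (0.15 log units; within the scatter) lies within the scatter, so the two compounds cannot be told apart on these figures.

Compound 3 `O=C(/C=C/c1ccccc1)c1ccc2ccccc2c1` has not yet been measured in this assay. It differs from compound 2 by hydrogen in place of chloro on an aromatic carbon; read one bond further out, the change is 3-chlorophenyl to phenyl, at a site meta to a large group.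

Going by the values given here, the only measured step that bears on this position is the one from compound 1 to compound 2, which exchanged nitro for chloro at the same aromatic carbon and moved the number by a 1.4-fold lower number from compound 1 to compound 2 (0.15 log units; within the scatter). Among the compounds with values here, no measured step removes a substituent from that carbon altogether, so the evidence is thin. With that one step within the scatter, little movement is expected in this assay in either direction. Compound 3 is estimated at 12000 nM, with a range from 5000 nM to 30000 nM. The expected step is a 1.2-fold higher number from compound 2 to compound 3 (0.08 log units; within the scatter), no larger than the usual scatter.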

Compound 3, half-maximal inhibitory concentration: 17000 nM
Compound 3: middle estimate off by 1.4-fold (0.15 log units), on the low side; the range from low to high includes it.
By their numbers in this assay, from the lowest: compounds 2, 1 and 3 (each within the scatter of the next).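

Going by these compounds alone, with compound 3, this aromatic carbon is seen for the first time carrying only hydrogen, and in this assay the unsubstituted ring cannot be told apart from either substituted one: a 1.7-fold higher number from compound 2 to compound 3 (0.23 log units; within the scatter) and a 1.2-fold higher number from compound 1 to compound 3 (0.08 log units; within the scatter) both lie within the scatter. Neither chloro nor nitro at this site, meta to a large group, is therefore shown to be needed for the cytotoxicity read here, and on these figures the three compounds form a single group with no ranking among them. Nothing available explains this flat picture or says what any of these groups does inside the cells.

The compounds shown leave open whether this site responds at all to other kinds of group, since an amine, a carboxylic acid or a methoxy group on the same carbon might or might not separate from these three. They also leave open whether replacing chloro with hydrogen would read the same way on another carbon of that ring or on a different core.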